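From dimethylamino to methoxy: an expected permeability reading

The source may hold more compounds than are shown below. What is called first, only, known or untested is meant among the compounds shown, and "the series" means these compounds.

Of the compounds shown here, three have so far been measured in an ADME assay for permeability, using PAMPA, at pH 7.4; on this read-out higher numbers stand for higher permeability and lower numbers for lower permeability. Compound 1 (`CN(C)c1ccccc1S(=O)(=O)Nc1ccc(-c2cccc(Cl)c2)nn1`) gives 35.7 10^-6 cm/s in this test and compound 2 (`Cc1ccc(S(=O)(=O)Nc2ccc(-c3ccccc3N(C)C)nn2)cc1`) shows the same 35.7 10^-6 cm/s reading. Compound 3 (`Cc1ccc(S(=O)(=O)Nc2ccc(-c3cccc4cccnc34)nn2)cc1`) gives 44.1 10^-6 cm/s and its gap to compound 2 lies within the usual scatter of repeated measurements, so the three numbers cannot be ranked.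

Compound 4 (`COc1ccccc1-c1ccc(NS(=O)(=O)c2ccc(C)cc2)nn1`) has not yet been measured. It differs from compound 2 in one place, with methoxy in place of dimethylamino on an aromatic carbon, ortho to a large group (methoxy in place of dimethylamino on an aromatic carbon). For the measured compounds named here, no two measured compounds differ in only one place, so no measured step shows what this swap does in this assay. Going by the values given here, the only guide is how close the measured compounds sit despite their different structures, with compound 2 at 35.7 10^-6 cm/s and compound 3 at 44.1 10^-6 cm/s on the same scale. No step beyond the scatter is therefore expected, and the estimated move is a 1.0-fold higher number from compound 2 to compound 4 (0.00 log units; within the scatter) in neither direction in particular. The estimate in this assay for compound 4 is 36 10^-6 cm/s with an expected range from 19 10^-6 cm/s to 65 10^-6 cm/s across repeat measurements.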

Compound 4, apparent permeability: 34.7 10^-6 cm/s
Estimate against measurement, compound 4: 1.0-fold (0.02 log units) above; measured number inside the range.
By their numbers in this assay, from the lowest: compounds 4, 1, 2 and 3 (each within the scatter of the next).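

For the compounds shown here, this is the first measured step at this position: in this assay, methoxy in place of dimethylamino on an aromatic carbon, ortho to a large group, gives a 1.0-fold lower number from compound 2 to compound 4 (0.01 log units; within the scatter). For this one pair, then, the two groups cannot be told apart on this read-out, even though the group that leaves has 3 heavy atoms, including a nitrogen, and the group that enters has 2, including an oxygen. No supporting measurement is available to explain why the two readings match.

This single pair cannot show whether a group of another kind at the same place, such as a carboxylic acid, a primary amine or a longer chain like butoxy, would also stay within the scatter of compound 2. It also leaves open whether the same swap would give a similar result in compound 1, which carries dimethylamino on a different part of the molecule and has a different group elsewhere.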